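The compounds below may be only part of what the source reports. "The series", "measured", "known", "first", "only" and "open" are said of these compounds alone.

Working notes on the series, read in a functional assay on SW480 cells (Homo sapiens) for antiproliferative activity, read by MTT assay, with a stated time of 48 h; a higher number here means a weaker inhibitor, a lower number a stronger inhibitor. Compound 1 (`CC(CCO)n1cnc2c(Cl)ncnc21`) gives > 50000 nM. That value is a limit of the assay and not a number.

Compound 2 (`CCCCCCC(CCO)n1cnc2c(Cl)ncnc21`) gives 16700 nM, and an at least 2.9-fold lower number from compound 1 to compound 2 (0.47 log units; beyond the scatter) comes with pentyl in place of hydrogen on a saturated chain carbon. For the measured compounds named here, compound 3 (`CCCCCCCC[C@@H](CCO)n1cnc2c(Cl)ncnc21`) gives 2330 nM, the lowest number so far and clearly under the value of compound 2.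

Compound 4 (`CCCCCCCCC(CCO)n1cnc2c(Cl)ncnc21`) follows with the two compounds have the same atoms and bonds; at least one stereo element is drawn with a configuration in one of them and without one in the other: 1 of 1 stereo elements differ; a stereocentre at a saturated chain carbon is drawn S in compound 3 and without a configuration in compound 4: a stereocentre at a saturated chain carbon is drawn S in compound 3 and without a configuration in compound 4. Going by the values given here, no measured step isolates a change of this kind. an at least 2.9-fold lower number from compound 1 to compound 2 (0.47 log units; beyond the scatter) alters the chain, so it gives no size for this one.

With the same atoms and bonds as compound 3 at 2330 nM, no step beyond the scatter is foreseen in this assay, and any drift would be slight, towards a higher number. The expected step is a 1.2-fold higher number from compound 3 to compound 4 (0.08 log units; within the scatter). For compound 4 the estimated value is 2800 nM, with an expected range of 1500 nM to 5500 nM.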

Compound 4, half-maximal inhibitory concentration: 1370 nM
For compound 4 the middle estimate is 2.0-fold (0.31 log units) above the measured one; the measured number lies below the stated range.
By their numbers in this assay, from the lowest: compounds 4 and 3 (each within the scatter of the next); then compound 2. At a limit, above all of these: compound 1.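

Compounds 3 and 4 cannot be told apart in this assay, a 1.7-fold lower number from compound 3 to compound 4 (0.23 log units; within the scatter), and what this pair says about configuration is limited: the fact that one of compounds 3 and 4 is drawn with a defined configuration and the other without, at the place where they differ. Ethyl in place of hydrogen on a saturated chain carbon, seven bonds along the chain from an aromatic nitrogen, gives a 12-fold lower number from compound 2 to compound 4 (1.09 log units; beyond the scatter), so chain length at this position still counts at the long end of the series. Taken from the shortest chain of the series to the longest, the change is an at least 36-fold lower number from compound 1 to compound 4 (1.56 log units; beyond the scatter), a step that starts from a limit of the assay: the limit of > 50000 nM in this assay, at which 1 of the 4 values shown sits.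

The compounds shown leave open whether a longer chain would carry the trend further or end it. They also leave open how a compound drawn with the opposite configuration at this stereocentre would read.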